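Anilide para-substituent variation in a triazole carboxamide series

A few compounds are considered here, and "the series" means these few. Any claim that something is new, unique, unknown or untested is made for them only; others in the source may bear on it.

Measured compounds:
compound 1 `COc1ccc(NC(=O)c2nc(-c3cc(OC)c(OC)c(OC)c3)n(-c3ccc(OC)cc3)n2)cc1` — 63%
compound 2 `COc1ccc(-n2nc(C(=O)Nc3ccc(C)cc3)nc2-c2cc(OC)c(OC)c(OC)c2)cc1` — 58%
compound 3 `COc1ccc(-n2nc(C(=O)Nc3ccc(C(F)(F)F)cc3)nc2-c2cc(OC)c(OC)c(OC)c2)cc1` — 56%

The three compounds share one core and differ only in the group on the anilide ring. In a functional assay on the whole organism for inhibition, with Rattus norvegicus as the target, read by paw edema, with stated times of 30 min and 4 h, at a dose of 0.28 mmol/kg by the oral route (a lower number here means less inhibition, a higher number more inhibition at the dose given (going by the name of the read-out)), compound 1 gives 63%. The other two numbers lie within the scatter of it: a number 5 percentage points lower from compound 1 to compound 2 (within the scatter) and a number 7 percentage points lower from compound 1 to compound 3 (within the scatter), and between them a number 2 percentage points lower from compound 2 to compound 3 (within the scatter). So none of the exchanges at this position has moved the read-out beyond the scatter.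

Compound 4 `COc1ccc(-n2nc(C(=O)Nc3ccccc3)nc2-c2cc(OC)c(OC)c(OC)c2)cc1` has not been measured. It differs from compound 1 by hydrogen in place of methoxy on an aromatic carbon. Within the data shown here, the steps that bear on it are the exchanges of the same methoxy for methyl and for trifluoromethyl, a number 5 percentage points lower from compound 1 to compound 2 (within the scatter) and a number 7 percentage points lower from compound 1 to compound 3 (within the scatter), both within the scatter. A hydrogen at the same place is expected to behave alike, with no step beyond the scatter, so the estimate for compound 4 is 58% (range 46% to 70%), a step of a number 5 percentage points lower from compound 1 to compound 4 (within the scatter) that is expected to remain within the scatter.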

Compound 4, a percentage reported as inhibition, in the whole organism at one dose (the size of the read-out at that dose, not a potency): 50%
For compound 4 the middle estimate is 8 percentage points above the measured one; the measured number falls inside the stated range.
By their numbers in this assay, from the lowest: compounds 4, 3, 2 and 1 (each within the scatter of the next, the first and the last beyond it).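

In this assay, among these compounds, the loss of the methoxy from the 4-methoxyphenyl group, with nothing in its place, is the first exchange at this position to pass the scatter: a number 13 percentage points lower from compound 1 to compound 4 (beyond the scatter) and the step is modest, whereas methyl and trifluoromethyl in the same place did not pass it. The anilino compound does not separate from the two other substituted anilides, with a number 6 percentage points lower from compound 3 to compound 4 (within the scatter) and a number 8 percentage points lower from compound 2 to compound 4 (within the scatter) so the only gap beyond the scatter in the set has methoxy at one end and hydrogen at the other. Nothing measured here offers a reason for this step.

On these data alone, whether a hydroxy, an ethoxy or an amine at this carbon would match methoxy or hydrogen stays open. Also open is whether the step holds at other doses, since one dose is shown.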